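The source may report more compounds than this note shows. Statements on the series, on what has been measured and on what is new or still open speak of the compounds shown alone.

Of the compounds shown here, two built on one shared core have been tested in a functional assay on HEK293 cells for antagonist activity at thromboxane A2 receptor (Homo sapiens), read by fluorescence and calcium flux; on this read-out lower numbers stand for stronger inhibition and higher numbers for weaker inhibition. Compound 1 `CCCCCNC(=O)NS(=O)(=O)c1cc(C#N)ccc1Oc1ccc(C)cc1` gives 900 nM. Compound 2 `CC(C)NC(=O)NS(=O)(=O)c1cc(C#N)ccc1Oc1ccc(F)cc1` gives 9620 nM; of the two numbers this is the higher, and its distance from the number of compound 1 lies beyond the usual scatter. These two compounds differ from each other in more than one place. Among the compounds with values here, their values set no step for any single change. Compound 3 `CCCCCNC(=O)NS(=O)(=O)c1cc(C#N)ccc1Oc1ccc(F)cc1` is the unmeasured neighbour of compound 2, reached by one change: pentyl in place of isopropyl on an amide-type nitrogen. Compound 3 thereby carries the pentyl group that compound 1 carries, with the rest of compound 2 kept unchanged. Within the data shown here, since the only pentyl compound measured, compound 1, stands at 900 nM, the step from compound 2 to compound 3 is expected to lower the number beyond the scatter, estimated at a 5.3-fold lower number from compound 2 to compound 3 (0.73 log units; beyond the scatter). Compound 3 is therefore estimated at 1800 nM, within a range from 500 nM to 6000 nM.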

Compound 3, half-maximal inhibitory concentration: 9430 nM
For compound 3 the middle estimate is 5.2-fold (0.72 log units) below the measured one; the measured number lies above the stated range.
By their numbers in this assay, from the lowest: compound 1; then compounds 3 and 2 (each within the scatter of the next).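

In this assay, pentyl in place of isopropyl on the amide-type nitrogen gives a 1.0-fold lower number from compound 2 to compound 3 (0.01 log units; within the scatter), so with fluoro on the aromatic carbon, these two chains cannot be told apart at this position. With pentyl held in place, fluoro in place of methyl on the aromatic carbon gives a 10-fold higher number from compound 1 to compound 3 (1.02 log units; beyond the scatter), the only single change shown so far that moves the number beyond the scatter. Nothing available gives a reason for either step. The compounds shown leave open whether pentyl and isopropyl would also match with methyl on that aromatic carbon. They also leave open what a chloro or methoxy group on that carbon, or a cyclohexyl group or longer chain on the nitrogen, would do to the number.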